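Aryl-triazole series: substituted phenyl rings on the shared core

The source may report more compounds than this note shows. Statements on the series, on what has been measured and on what is new or still open speak of the compounds shown alone.

Three analogues of one core have been measured. Compound 1 `CC(C)=CCC/C(C)=C/CC/C(C)=C/CC[C@@H]1[C@@]2(C)CC/C(=N\OCc3cn(-c4ccccc4)nn3)C(C)(C)[C@@H]2CC[C@@]1(C)O` carries a plain phenyl on the triazole nitrogen. In a functional assay on HepG2 cells (Homo sapiens) for cytotoxicity, read by MTT assay, with a stated time of 48 h (on this read-out higher numbers stand for weaker inhibition and lower numbers for stronger inhibition), compound 1 gives 9520 nM, the lowest number of the three. Compound 2 `CC(C)=CCC/C(C)=C/CC/C(C)=C/CC[C@@H]1[C@@]2(C)CC/C(=N\OCc3cn(-c4cccc([N+](=O)[O-])c4)nn3)C(C)(C)[C@@H]2CC[C@@]1(C)O` gives 22000 nM in this assay, and compound 3 `CC(C)=CCC/C(C)=C/CC/C(C)=C/CC[C@@H]1[C@@]2(C)CC/C(=N\OCc3cn(-c4cccc(O)c4)nn3)C(C)(C)[C@@H]2CC[C@@]1(C)O` gives 21200 nM. The two substituted rings sit at about the same level, while both moves away from compound 1 are modest: a 2.3-fold higher number from compound 1 to compound 2 (0.36 log units; beyond the scatter) and a 2.2-fold higher number from compound 1 to compound 3 (0.35 log units; beyond the scatter). Between the two substituted analogues the difference is within the scatter, a 1.0-fold lower number from compound 2 to compound 3 (0.02 log units; within the scatter).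

Compound 4 `CC(C)=CCC/C(C)=C/CC/C(C)=C/CC[C@@H]1[C@@]2(C)CC/C(=N\OCc3cn(-c4ccc(F)c(Cl)c4)nn3)C(C)(C)[C@@H]2CC[C@@]1(C)O` has not yet been measured. It differs from compound 1 by 3-chloro-4-fluorophenyl in place of phenyl on an aromatic nitrogen. The two measured steps that bear on it are the single substitutions on the same ring, each of which gave a modest rise in number; neither a halogen nor a doubly substituted ring has been tested in this series, so the comparison is loose. On that basis a modest rise in the number is expected for compound 4, in the same direction as the two single substitutions on that ring, a 1.7-fold higher number from compound 1 to compound 4 (0.23 log units; within the scatter). The estimate for compound 4 in this assay is 16000 nM, with a plausible range from 6500 nM to 38000 nM.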

Compound 4, half-maximal inhibitory concentration: 58900 nM
Compound 4: the middle estimate sits 3.7-fold (0.57 log units) below what was measured; measured number outside the range, above it.
By their numbers in this assay, from the lowest: compound 1; then compounds 3 and 2 (each within the scatter of the next); then compound 4.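

Among these compounds, the aromatic group on the nitrogen of the five-membered aromatic ring with 3 nitrogen is more sensitive to substitution than the single substitutions indicated: in this assay, 3-chloro-4-fluorophenyl in place of phenyl gives a 6.2-fold higher number from compound 1 to compound 4 (0.79 log units; beyond the scatter) and is the largest step so far. The substituted rings also no longer sit at one level, since 3-chloro-4-fluorophenyl gives a 2.8-fold higher number from compound 3 to compound 4 (0.44 log units; beyond the scatter) and a 2.7-fold higher number from compound 2 to compound 4 (0.43 log units; beyond the scatter), placing compound 4 at the highest number, with all three of its steps beyond the scatter; all three substituted rings now stand above plain phenyl, and none of the four compounds goes against that. Nothing in the data shown accounts for the size of this step.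

Open, as far as these compounds go, is how a 3-chlorophenyl or a 4-fluorophenyl alone would compare with compound 4, and therefore whether one halogen or the pair carries the step. Also open, from the compounds shown here alone, is whether an amine or a carboxylic acid on this ring, or a benzyl in place of phenyl, would bring the number back towards that of compound 1 or beneath it.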